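The compounds below may be only part of what the source reports. "The series", "measured", "known", "first", "only" and "open" are said of these compounds alone.

Compound 1 `O=C(/C=C\Nc1ccc(C(F)(F)F)cc1)c1cn(-c2ccccc2)nc1-c1ccc(F)cc1`: > 50000 nM
Compound 2 `O=C(/C=C\Nc1ccc(C(F)(F)F)cc1)c1cn(-c2ccccc2)nc1-c1ccc(Cl)cc1`: > 50000 nM
Compound 3 `COc1ccc(-c2nn(-c3ccccc3)cc2C(=O)/C=C\Nc2ccc(F)cc2)cc1`: 3980 nM

Compound 3 is the only one of the three measured compounds that gives a number in a functional assay on A549 cells (Homo sapiens) for antiproliferative activity, read by MTT assay, with a stated time of 48 h; a lower number here means a stronger inhibitor, a higher number a weaker inhibitor: compound 3 gives 3980 nM. Compound 1 reaches only a limit there, > 50000 nM. Compound 2 likewise reaches only a limit, > 50000 nM. The step that the two limits leave unreadable from compound 1 to compound 2 therefore cannot be read, since both compounds sit at the limit of > 50000 nM in this assay, at which 2 of the 3 values shown sit.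

Compound 4 `COc1ccc(-c2nn(-c3ccccc3)cc2C(=O)/C=C\Nc2ccc(C(F)(F)F)cc2)cc1` is compound 3 with one change: trifluoromethyl in place of fluoro on an aromatic carbon. Within the data shown here, no measured step follows this same change, so nothing gives its size directly. Among the measured compounds shown here, compounds 1 and 2 both carry the (4-(trifluoromethyl)phenyl)amino group and both stop at the limit, but each also differs from compound 3 elsewhere, so their values show only that this group went with no readable activity in those two cases. On that thin footing, compound 4 is expected to be a weaker inhibitor than compound 3. For compound 4 the expected step is a 5.0-fold higher number from compound 3 to compound 4 (0.70 log units; beyond the scatter), toward weaker inhibition, with a real chance that this assay again reports only a limit. The estimate for compound 4 is 20000 nM, within 4000 nM to 80000 nM.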

Compound 4, half-maximal inhibitory concentration: > 50000 nM
Compound 4: a limit, no number; the forecaster's own chance of this, stated with the estimate: 35%; middle value at least 2.5-fold (0.39 log units) from the limit.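

Compound 3 and compound 4 differ only at this one place, which gives a readable size for this change in this assay: an at least 12-fold higher number from compound 3 to compound 4 (1.09 log units; beyond the scatter). Compounds 1 and 2 could only hint at this, as each also differs from compound 3 elsewhere, whereas this pair ties the loss of a measurable number directly to going from (4-fluorophenyl)amino to (4-(trifluoromethyl)phenyl)amino. The steps linking compound 4 to compound 1 and compound 2 cannot be read, so methoxy, fluoro and chloro cannot be ranked when trifluoromethyl is present, and all three compounds stand at a limit: the limit of > 50000 nM in this assay, at which 3 of the 4 values shown sit.

As far as these compounds go, it stays open whether a nitrile or a methyl group at this same place would keep a measurable number. Also open, from the compounds shown here alone, is how chloro in place of methoxy would read with the fluoro group kept.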